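Chloro to Methyl on an Aromatic Carbon

This account rests on a few compounds, and the source may have more. Where it says the series, first, only, none or still open, it means among the compounds named here.

Three compounds were measured in an assay on MDA-MB-231 cells for binding affinity to C-X-C chemokine receptor type 4 (Homo sapiens), read by immunofluorescence and microscopy, with stated times of 10 min and 30 min; on this read-out higher numbers stand for an effect only at larger amounts of compound and lower numbers for an effect already at smaller amounts:
compound 1 `O=C(NCc1ccc(CNS(=O)(=O)c2ccccc2)cc1)c1ccccc1Cl`, 10 nM
compound 2 `Cc1ccc(S(=O)(=O)NCc2ccc(CNC(=O)c3ccc([N+](=O)[O-])cc3)cc2)cc1`, 10 nM
compound 3 `Cc1ccc(S(=O)(=O)NCc2ccc(CNC(=O)c3ccccc3Cl)cc2)cc1`, 10 nM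

Compound 1 stands level with compounds 2 and 3, all three within the scatter of one another. Compound 4 `Cc1ccccc1C(=O)NCc1ccc(CNS(=O)(=O)c2ccccc2)cc1` differs from compound 1 in one place: methyl in place of chloro on an aromatic carbon. Within the data shown here, no measured step exchanges a chloro for a methyl, but two steps on the shared core bear on it: no change at the digits printed from compound 1 to compound 3 (within the scatter) and no change at the digits printed from compound 2 to compound 3 (within the scatter). One adds a small group to an aromatic ring, the other swaps the whole ring on the carbonyl carbon, and neither moved the read-out beyond the scatter. The step to compound 4 is therefore expected to be no change at the digits printed from compound 1 to compound 4 (within the scatter), no change beyond the scatter. Compound 4 is estimated at 10 nM, between 4 nM and 25 nM.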

Compound 4, effective concentration (reported as EC, without a stated level of effect): 1 nM
Compound 4: the middle estimate sits 10-fold (1.00 log units) above what was measured, outside the stated range (below it).
By their numbers in this assay, from the lowest: compound 4; then compounds 1, 2 and 3 (each within the scatter of the next).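

Among these compounds, exchanging 2-chlorophenyl for 2-methylphenyl gives the first step on this shared core that goes beyond the scatter (a 10-fold lower number from compound 1 to compound 4 (1.00 log units; beyond the scatter)). So this position responds to a change that leaves the counts of heavy atoms, hydrogen-bond donors and hydrogen-bond acceptors the same, something the earlier steps did not show. Nothing available explains the shift.

Going by these compounds, whether an ethyl, a methoxy or an amine at this position would give a similar number remains open. So does whether the same exchange would act alike on compound 3.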